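The source may report more compounds than this note shows. Statements on the series, on what has been measured and on what is new or still open speak of the compounds shown alone.

Measured compounds:
compound 1 `COc1ccc(Cl)cc1S(=O)(=O)Nc1cncc(C(=O)Nc2ccccc2)c1` with 310 nM
compound 2 `COc1ccc(Cl)cc1S(=O)(=O)Nc1cncc(-c2ccc(Cl)cc2)c1` with 198 nM
compound 3 `COc1ccc(Cl)cc1S(=O)(=O)Nc1cncc(C(=O)O)c1` with 134 nM

In an assay on isolated protein for inhibition of alkaline phosphatase, tissue-nonspecific isozyme (Homo sapiens) (a lower number here means a stronger inhibitor, a higher number a weaker inhibitor), compound 3 gives the lowest of the three numbers; it lies within the scatter of compound 2, and the step of a 2.3-fold lower number from compound 1 to compound 3 (0.36 log units; beyond the scatter) is the only one in the set that exceeds the scatter. The step of a 1.5-fold lower number from compound 2 to compound 3 (0.17 log units; within the scatter) and the step of a 1.6-fold lower number from compound 1 to compound 2 (0.19 log units; within the scatter) are both within the scatter.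

Compound 4 `CNC(=O)c1cncc(NS(=O)(=O)c2cc(Cl)ccc2OC)c1` is not yet measured. Its change from compound 3 is methylamino in place of hydroxy on a carbonyl carbon. Going by the values given here, the one measured step that bears on it is a 2.3-fold lower number from compound 1 to compound 3 (0.36 log units; beyond the scatter), where the amide of compound 1 went to the acid of compound 3 with a modest fall in the number. Compound 4 runs that change the other way, with a methylamino rather than an anilino group on the carbonyl carbon, so a modest rise in this assay is expected, roughly a 1.7-fold higher number from compound 3 to compound 4 (0.23 log units; within the scatter). For compound 4 the expected value is 230 nM, with a range from 110 nM to 500 nM.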

Compound 4, half-maximal inhibitory concentration: 109 nM
Estimate against measurement, compound 4: 2.1-fold (0.32 log units) above; measured number below the stated range.
By their numbers in this assay, from the lowest: compounds 4, 3, 2 and 1 (each within the scatter of the next, the first and the last beyond it).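

In this assay, the carbonyl carbon accepts methylamino as readily as hydroxy, with a 1.2-fold lower number from compound 3 to compound 4 (0.09 log units; within the scatter), and methylcarbamoyl on the aromatic carbon cannot be separated from 4-chlorophenyl, with a 1.8-fold lower number from compound 2 to compound 4 (0.26 log units; within the scatter) as the step. The higher number of compound 1 therefore goes with the phenyl on the amide-type nitrogen and not with the amide as such, since methyl in its place gives a 2.8-fold lower number from compound 1 to compound 4 (0.45 log units; beyond the scatter) as a step beyond the scatter. Nothing on hand explains these differences.

Still open, as far as these compounds go, is how far the amide-type nitrogen accepts groups between methyl and phenyl, such as ethyl, cyclopropyl or benzyl. Also open, from the compounds shown here alone, is whether dimethylamino on the carbonyl carbon, or a nitrile or primary amine on the aromatic carbon, stays in the same range.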